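A Benzyl Group in Place of Trifluoromethyl

The source may report more compounds than this note shows. Statements on the series, on what has been measured and on what is new or still open speak of the compounds shown alone.

Compound 1 `Cc1cc(C)cc(NC(=O)COc2cc(C)nc3ccc(Cl)cc23)c1`: 6.38
Compound 2 `Cc1cc(C)cc(NC(=O)COc2cc(C)nc3ccc(OC(F)(F)F)cc23)c1`: 6.79

Both compounds were read in a physicochemical assay for lipophilicity, read by HPLC, in phosphate buffer, measured as chromatographic lipophilicity, at pH 7.4; on this read-out lower numbers stand for lower lipophilicity and higher numbers for higher lipophilicity. Compound 2 stands highest of the two numbers, separated from compound 1 by a number 0.41 log units higher from compound 1 to compound 2 (beyond the scatter). Compound 3 `Cc1cc(C)cc(NC(=O)COc2cc(C)nc3ccc(OCc4ccccc4)cc23)c1` differs from compound 2 by benzyl in place of trifluoromethyl on an oxygen on an aromatic ring. Among the compounds with values here, no measured step covers this exchange: the single step seen so far swaps chloro for trifluoromethoxy, a different change. With only that modest rise available as a guide, compound 3 is expected to read higher than compound 2 by an estimated a number 0.51 log units higher from compound 2 to compound 3 (beyond the scatter). The estimate for compound 3 is therefore 7.3, within a range of 6.8 to 7.8.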

Compound 3, distribution coefficient: 7.03
The estimate for compound 3 lay 0.27 log units above the measured number, within the range that was stated.
By their numbers in this assay, from the lowest: compound 1; then compounds 2 and 3 (each within the scatter of the next).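

In this assay the exchange of trifluoromethyl for benzyl on an oxygen on an aromatic ring gives a number 0.24 log units higher from compound 2 to compound 3 (within the scatter) and so leaves trifluoromethoxy and benzyloxy unseparated, although benzyl brings an aromatic ring that trifluoromethyl lacks. Measured against chloro, benzyloxy gives a number 0.65 log units higher from compound 1 to compound 3 (beyond the scatter) and so joins trifluoromethoxy in a step beyond the scatter. Nothing measured here bears on the reason for this result.

Going by these compounds, whether a carboxylic acid or an amine carried on a longer chain at this oxygen would read differently remains open.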